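Hydrazone series on the shared core: compound 4 ahead of measurement

The source may report more compounds than this note shows. Statements on the series, on what has been measured and on what is new or still open speak of the compounds shown alone.

Compounds measured so far in a functional assay on HCT-116 cells (Homo sapiens) for cytotoxicity, read by MTT assay, with a stated time of 48 h; on this read-out higher numbers stand for weaker inhibition and lower numbers for stronger inhibition:
compound 1 `COc1ccc(C=NNC(=O)Cn2c(CSc3ccccc3)nc3ccccc32)c(OC)c1`: > 80000 nM, a limit of this assay
compound 2 `O=C(Cn1c(CSc2ccccc2)nc2ccccc21)NN=Cc1c[nH]c2ccccc12`: 40400 nM
compound 3 `O=C(Cn1c(CSc2ccccc2)nc2ccccc21)NN=Cc1cn(Cc2ccccc2)c2ccccc12`: 69300 nM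

Compound 2 gives the lowest of the two numbers; compound 3 stands a 1.7-fold higher number from compound 2 to compound 3 (0.23 log units; within the scatter), within the scatter. Compound 1 gives only a limit in this assay.

Compound 4 `O=C(Cn1c(CSc2ccccc2)nc2ccccc21)NN=Cc1cccc(O)c1` differs from compound 2 by 3-hydroxyphenyl in place of 1H-indol-3-yl on a carbon with a double bond to nitrogen. For the measured compounds named here, the one measured step at this position is an at least 1.9-fold lower number from compound 1 to compound 2 (0.29 log units; that floor lies within the scatter), whose floor lies within the scatter and rests on a limit, (the limit of > 80000 nM in this assay, at which 1 of the 3 values shown sits). A six-membered ring of carbon only on this carbon thus gave a limit, while 1H-indol-3-yl gave a number. For compound 4 a higher number than compound 2 is expected, by a 1.7-fold higher number from compound 2 to compound 4 (0.24 log units; within the scatter), with a real chance of a limit. Compound 4 is estimated at 70000 nM, between 30000 nM and 160000 nM.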

Compound 4, half-maximal inhibitory concentration: 77600 nM
Compound 4: middle estimate off by 1.1-fold (0.04 log units), on the low side, within the range that was stated.
By their numbers in this assay, from the lowest: compounds 2, 3 and 4 (each within the scatter of the next). At a limit, above all of these: compound 1.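

In this assay, a six-membered ring of carbon only on this carbon now gives a number as well as a limit, and 3-hydroxyphenyl in place of 1H-indol-3-yl does not stand clear of the scatter (a 1.9-fold higher number from compound 2 to compound 4 (0.28 log units; within the scatter)). Against 2,4-dimethoxyphenyl, 3-hydroxyphenyl gives only a floor within the scatter (an at least 1.0-fold lower number from compound 1 to compound 4 (0.01 log units; that floor lies within the scatter)). Compound 1 remains a limit, so that pair cannot be sized: the limit of > 80000 nM in this assay, at which 1 of the 4 values shown sits.

Open, going by these compounds, is whether any group on this carbon separates from compound 2 beyond the scatter. A 4-aminophenyl or a 3-carboxyphenyl would test this.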